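The compounds below may be only part of what the source reports. "The series", "measured", "known", "first", "only" and "open" are said of these compounds alone.

Compound 1 `CC#CCn1c(N2CCC[C@@H](N)C2)nc2c1c(=O)n(Cc1ccc(Br)cc1C(=O)OC)c(=O)n2C`: in an ADME assay on isolated protein for inhibition of Dipeptidyl peptidase 9 (Homo sapiens), with stated times of 15 min, 60 s and 20 min (a higher number here means a weaker inhibitor, a lower number a stronger inhibitor), compound 1 gives > 100000 nM, which is a limit of the assay and not a number.
Compound 2 `CC#CCn1c(N2CCC[C@@H](N)C2)nc2c1c(=O)n(Cc1ccccc1C(=O)O)c(=O)n2C`: compound 2 gives > 100000 nM, again a limit of the assay.
Compound 3 `CC#CCn1c(N2CCC[C@@H](N)C2)nc2c1c(=O)n(Cc1cc(Br)ccc1C(=O)O)c(=O)n2C`: compound 3 gives > 100000 nM, again a limit of the assay.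

Compound 1 therefore stands nowhere on a scale of numbers: it sits at the limit, and so do the other two values, since (the limit of > 100000 nM in this assay, at which 3 of the 3 values shown sit). Compound 4 `CC#CCn1c(N2CCC[C@@H](N)C2)nc2c1c(=O)n(Cc1cc(Cl)ccc1C(=O)O)c(=O)n2C` differs from compound 1 in one place (2-carboxy-5-chlorophenyl in place of 4-bromo-2-(methoxycarbonyl)phenyl on a saturated chain carbon bound to an aromatic nitrogen). Going by the values given here, three measured steps bear on this change. The first, a step that the two limits leave unreadable from compound 1 to compound 2, the second, a step that the two limits leave unreadable from compound 1 to compound 3, and the third, a step that the two limits leave unreadable from compound 2 to compound 3, are all of unreadable size because the limit of > 100000 nM in this assay, at which 3 of the 3 values shown sit, covers every measured compound. Nothing here shows any change strong enough to pull a compound below the limit. For compound 4 the expected step is a step that the limit leaves unreadable from compound 1 to compound 4, meaning no readable change. Compound 4 is estimated at 200000 nM, with a range from 50000 nM to 1000000 nM, most likely reported again only as a limit.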

Compound 4, half-maximal inhibitory concentration: > 100000 nM
Compound 4 was reported as a limit (the forecaster's own chance of this, stated with the estimate: 85%); the middle value is on the limit's open side.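

No size can be read for the steps linking compound 4 to compound 1, compound 2 or compound 3, since each value is a limit and not a number: the limit of > 100000 nM in this assay, at which 4 of the 4 values shown sit.

The compounds shown leave open how strongly any of them acts in this assay, and whether bromo, chloro or hydrogen on the aromatic carbon makes any difference there.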